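The source may hold more compounds than are shown below. What is called first, only, known or untested is meant among the compounds shown, and "the series" means these compounds.

Series notes. All three compounds share one core carrying an arylamino group. Compound 1 `O=C1C(Nc2ccccc2)=CC(=O)c2c1nc1n2[C@H]2OC[C@@H](O)[C@H]2OC1` bears an unsubstituted phenylamino group; compound 2 `CCc1ccc(NC2=CC(=O)c3nc4n(c3C2=O)[C@H]2OC[C@@H](O)[C@H]2OC4)cc1` bears a (4-ethylphenyl)amino group. In a functional assay on HeLa cells (Homo sapiens) for inhibition, read by sulforhodamine B assay (on this read-out lower numbers stand for stronger inhibition and higher numbers for weaker inhibition), compound 1 gives only a limit, > 8000 nM, not a number. In this assay, within the data shown here, compound 2 gives 3990 nM, the only number measured so far, the other value being (the limit of > 8000 nM in this assay, at which 1 of the 2 values shown sits). Compound 3 `Cc1ccc(NC2=CC(=O)c3nc4n(c3C2=O)[C@H]2OC[C@@H](O)[C@H]2OC4)cc1` carries a (4-methylphenyl)amino group; against compound 2 the change is hydrogen in place of methyl on a saturated chain carbon bound to an aromatic carbon. Among the measured compounds shown here, no step between two measured compounds exists to lean on. Because compound 1 stands at the limit of > 8000 nM in this assay, at which 1 of the 2 values shown sits, removing part of the chain is expected to cost a little, probably within the scatter, in this assay; the expected step from compound 2 to compound 3 is a 1.3-fold higher number from compound 2 to compound 3 (0.10 log units; within the scatter). Compound 3 is thus estimated at 5000 nM, in the range 2500 nM to 12000 nM.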

Compound 3, half-maximal inhibitory concentration: 3860 nM
Compound 3: middle estimate off by 1.3-fold (0.11 log units), on the high side; low and high end bracket the measured number.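

In this assay, among these compounds, cutting the ethyl of the (4-ethylphenyl)amino group back to the methyl of the (4-methylphenyl)amino group gives a 1.0-fold lower number from compound 2 to compound 3 (0.01 log units; within the scatter), the first step read between two numbers. Removing this one carbon, on a saturated chain carbon bound to an aromatic carbon, thus leaves the read-out within the scatter, and ethyl and methyl cannot be told apart here. Compound 1, with its unsubstituted phenylamino group, gives only a limit, so steps from it to the other two compounds cannot be read: the limit of > 8000 nM in this assay, at which 1 of the 3 values shown sits.

Going by these compounds, what a longer chain such as propyl or butyl, or an amine or a carboxylic acid in the same place, would do in this assay stays open. Also open, on these data alone, is how far compound 1 truly lies from the two substituted compounds.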